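This account rests on a few compounds, and the source may have more. Where it says the series, first, only, none or still open, it means among the compounds named here.

Compounds measured so far in a functional assay on HCC827 cells (Homo sapiens) for antiproliferative activity, read by MTT assay, with a stated time of 72 h; on this read-out higher numbers stand for weaker inhibition and lower numbers for stronger inhibition:

compound 1 `CN1CCN(c2ccc(Nc3ncc4nc(Nc5ccc(F)cc5)n([C@H]5CCCN(S(=O)(=O)C6CC6)C5)c4n3)cc2)CC1` — 8.6 nM
compound 2 `CN1CCN(c2ccc(Nc3ncc4nc(Nc5ccccc5)n([C@H]5CCNC5)c4n3)cc2)CC1` — 530 nM
compound 3 `CC(=O)N1CC[C@H](n2c(Nc3ccccc3)nc3cnc(Nc4ccc(N5CCN(C)CC5)cc4)nc32)C1` — 260 nM

Compound 1 gives the lowest number of the three; compound 3 sits nearest to it and compound 2 furthest, both gaps beyond the scatter. Compound 2 and compound 3 differ only by acetyl in place of hydrogen on an amine nitrogen in a ring, and that step, a 2.0-fold lower number from compound 2 to compound 3 (0.31 log units; beyond the scatter), is modest but beyond the scatter.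

Compound 4 `CN1CCN(c2ccc(Nc3ncc4nc(Nc5ccc(F)cc5)n([C@@H]5CCN(C(=O)OC(C)(C)C)C5)c4n3)cc2)CC1` is unmeasured. It differs from compound 1 by 1-(tert-butoxycarbonyl)pyrrolidin-3-yl in place of 1-(cyclopropylsulfonyl)piperidin-3-yl on an aromatic nitrogen. For the measured compounds named here, no single measured step covers this change. Going by the values given here, the only step that bears on it is the acylation of the ring amine in a 2.0-fold lower number from compound 2 to compound 3 (0.31 log units; beyond the scatter), which moved the number down somewhat; the pair compound 1 and compound 3 differ in two places at once, and their values show only that the sulfonylpiperidine compound gives the lower number. The change to the tert-butoxycarbonyl pyrrolidine is therefore expected to raise the number of compound 4 relative to compound 1, by a step estimated at a 7.0-fold higher number from compound 1 to compound 4 (0.84 log units; beyond the scatter), with wide uncertainty. Compound 4 is estimated at 60 nM, in a range from 15 nM to 250 nM.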

Compound 4, half-maximal inhibitory concentration: 27 nM
The estimate for compound 4 lay 2.2-fold (0.35 log units) above the measured number, within the range that was stated.
By their numbers in this assay, from the lowest: compound 1; then compound 4; then compound 3; then compound 2.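

In this assay, this substituent on the aromatic nitrogen can be exchanged entirely with only a modest loss, a 3.1-fold higher number from compound 1 to compound 4 (0.50 log units; beyond the scatter), and compound 4 still gives 27 nM. The change replaces a six-membered ring with a five-membered one and a cyclopropylsulfonyl group with a tert-butoxycarbonyl group, keeping the same heavy-atom and hydrogen-bond acceptor counts, so a low number at this position does not depend on the 1-(cyclopropylsulfonyl)piperidin-3-yl group. No measurement on hand accounts for the size of this step.

The ring and its nitrogen substituent change together here, so their separate contributions cannot be read from this pair. Open too, going by these compounds, is how a 1-(methanesulfonyl)pyrrolidin-3-yl or 1-(tert-butoxycarbonyl)piperidin-3-yl group would compare at this position.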